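Swapping an aryl sulfonamide for an acetylpiperidine amide

A few compounds are considered here, and "the series" means these few. Any claim that something is new, unique, unknown or untested is made for them only; others in the source may bear on it.

Of the compounds shown here, two have been tested in an ADME assay on HEK293 cells (Homo sapiens) for cytotoxicity, read by resazurin assay, with a stated time of 48 h; on this read-out lower numbers stand for higher toxicity in this test and higher numbers for lower toxicity in this test. Compound 1, `COc1c(Br)cccc1C(=O)Nc1ccc(Sc2nc3ccccc3s2)c(Cl)c1`, gives 40000 nM in this assay. Compound 2, `COc1ccc(S(=O)(=O)Nc2ccc3oc(-c4ccc(NS(=O)(=O)c5cc(F)ccc5OC)cc4)nc3c2)cc1`, gives 24000 nM in this assay. The two readings lie within the usual scatter of each other, so on these numbers compound 2 is not told apart from compound 1; both sit at concentrations where cells begin to be harmed only at the high end of the tested range.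

Compound 3, `COc1ccc(S(=O)(=O)Nc2ccc3oc(-c4ccc(NC(=O)C5CCN(C(C)=O)CC5)cc4)nc3c2)cc1`, has not yet been measured. It differs from compound 2 by a group of 11 heavy atoms (8 carbon, 1 nitrogen, 2 oxygen; one six-membered non-aromatic ring with 1 hetero atom) in place of a group of 12 heavy atoms (7 carbon, 3 oxygen, 1 fluorine, 1 sulfur; one six-membered aromatic ring of carbon only), on a nitrogen on an aromatic ring. The part that leaves and the part that enters are of nearly the same size, and each carries two double bonds outside aromatic rings, but an aromatic ring gives way to a non-aromatic ring with one hetero atom, and the fluorine and sulfur are gone.

Among the measured compounds shown here, no measured pair tracks such a change here, so any expectation rests on compound 2 alone. The expected step of a 1.5-fold higher number from compound 2 to compound 3 (0.16 log units; within the scatter) is small and is not expected to exceed the scatter. For compound 3 the estimate in this assay is 35000 nM, within a range from 12000 nM to 100000 nM.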

Compound 3, half-maximal cytotoxic concentration: 34000 nM
The estimate for compound 3 lay 1.0-fold (0.01 log units) above the measured number, within the range that was stated.
By their numbers in this assay, from the lowest: compounds 2, 3 and 1 (each within the scatter of the next).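

In this assay, among the compounds shown here, the only step between compounds that differ in one place is a 1.4-fold higher number from compound 2 to compound 3 (0.15 log units; within the scatter). At this position, on a nitrogen on an aromatic ring, the (1-acetylpiperidin-4-yl)carbonyl group can therefore stand in place of the group holding a carbon-only aromatic ring, a fluorine and a sulfur, and the two readings cannot be told apart. Nothing available explains this result, and nothing measured here bears on why the number remains within the scatter.

The aromatic ring, the fluorine and the sulfur all leave in this single step, so the compounds shown cannot separate what each one contributes, and they include no step at this position that lies beyond the scatter. Going by these compounds, it remains open whether a plain acetyl group on this nitrogen, a piperidine ring with a free amine in place of the acetylated nitrogen, or a group carrying a carboxylic acid would also give a number within the scatter of these readings.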